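This account rests on a few compounds, and the source may have more. Where it says the series, first, only, none or still open, it means among the compounds named here.

Measured compounds:
Compound 1, `Cc1occc1-c1nnc2sc(Cc3ccccc3)nn12`, gives 13% in an assay for inhibition of histone-lysine N-methyltransferase, H3 lysine-79 specific (Homo sapiens), read by scintillation counting, with stated times of 15 min and 60 min, tested at 50 uM, in the presence of a further agent that is not named here; a lower number here means a weaker effect, a higher number a stronger effect of the compound at the concentration tested.
Compound 2, `Cc1occc1-c1nnc2sc(CCc3ccccc3)nn12`, gives 11% in this assay.
Compound 3, `c1ccc2c(Cc3nn4c(-c5ccoc5)nnc4s3)cccc2c1`, gives 59% in this assay.

Compound 2 stands at the bottom of the three numbers: compound 1 sits alongside it within the scatter, while compound 3, whose values differ from it in the side chain and in the substituted furan, lies beyond the scatter above it.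

Compound 4, `Cc1occc1-c1nnc2sc(CCCc3ccccc3)nn12`, has not yet been measured in this assay. It differs from compound 2 in one place: benzyl in place of phenyl on a saturated chain carbon, two bonds along the chain from an aromatic carbon. This is the same kind of lengthening already seen once in the series, one carbon further along the chain. That earlier step, from compound 1 to compound 2, gave a number 2 percentage points lower from compound 1 to compound 2 (within the scatter), so extending the chain by one carbon did not move the read-out beyond the scatter. Among the measured compounds shown here, no other measured pair bears directly on this change.

On that basis compound 4 is expected to remain close to compound 2, with a step of about no change at the digits printed from compound 2 to compound 4 (within the scatter) and no movement beyond the scatter. The estimate for compound 4 in this assay is therefore 11%, with a range from 0% to 26%.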

Compound 4, a percentage reported as inhibition, at one concentration (the size of the read-out at that concentration, not a potency): 17%
The estimate for compound 4 lay 6 percentage points below the measured number, within the range that was stated.
By their numbers in this assay, from the lowest: compounds 2, 1 and 4 (each within the scatter of the next); then compound 3.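

In this assay, the same one-carbon lengthening was now tested a second time, further along the chain, with benzyl in place of phenyl on a saturated chain carbon, two bonds along the chain from an aromatic carbon, and it gave a number 6 percentage points higher from compound 2 to compound 4 (within the scatter). Set beside the earlier step, a number 2 percentage points lower from compound 1 to compound 2 (within the scatter), this shows that neither of the two successive extensions of the chain between the shared core and the phenyl ring moved the read-out beyond the scatter, so across these compounds the length of the chain does not separate one from the next. The data offer no measurement that would explain this result.

Compound 3 gives 59% but differs from each of the other compounds in more than one place, so these compounds do not show whether its side chain, its unsubstituted furan or both together go with that number. On these data alone, it also remains open whether a longer chain, or an amine or a carboxylic acid in place of the phenyl at the end of the chain, would stay within the scatter of compound 4.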